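The source may hold more compounds than are shown below. What is called first, only, known or untested is meant among the compounds shown, and "the series" means these compounds.

In a functional assay on PANC-1 cells (Homo sapiens) for inhibition, read by MTT assay, with a stated time of 24 h, tested at 10 uM (a higher number here means more inhibition at the concentration tested (going by the name of the read-out), a lower number less inhibition), compound 3 `CC(C)=CCC/C(C)=C/CC1Cc2c(OCCCNC(=O)c3ccco3)cc(=O)n(CCCO)c2CC1(C)C` gives 2.8%, the highest of the three numbers, though within the scatter of both neighbours. Compound 1 `CC(C)=CCC/C(C)=C/CC1Cc2c(O)cc(=O)n(CCCO)c2CC1(C)C` gives 0% and compound 2 `CC(C)=CCC/C(C)=C/CC1Cc2c(OCCCNS(=O)(=O)c3ccc(Br)cc3)cc(=O)n(CCCO)c2CC1(C)C` gives 0%. Compound 4 `CC(C)=CCC/C(C)=C/CC1Cc2c(OCCCNC(=O)c3cccs3)cc(=O)n(CCCO)c2CC1(C)C` carries thiophen-2-yl in place of furan-2-yl on a carbonyl carbon. Among the compounds with values here, two measured steps bear on this change. The step of a number 2.8 percentage points higher from compound 1 to compound 3 (within the scatter) and the step of a number 2.8 percentage points higher from compound 2 to compound 3 (within the scatter) show that neither adding the whole side chain nor exchanging the sulfonyl for the carbonyl group moved this assay beyond its scatter. A swap of one five-membered ring for another on the carbonyl carbon is therefore expected to give no step beyond the scatter, and compound 4 is estimated at 3%, between -5% and 12%, the expected step being a number 0.2 percentage points higher from compound 3 to compound 4 (within the scatter).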

Compound 4, a percentage reported as inhibition, at one concentration (the size of the read-out at that concentration, not a potency): 11.5%
For compound 4 the middle estimate is 8.5 percentage points below the measured one; low and high end bracket the measured number.
By their numbers in this assay, from the lowest: compounds 1, 2, 3 and 4 (each within the scatter of the next, the first and the last beyond it).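

In this assay the exchange on the carbonyl carbon alone gives a number 8.7 percentage points higher from compound 3 to compound 4 (within the scatter) and so does not separate thiophen-2-yl from furan-2-yl. Even so, the thiophen-2-yl side chain is the first to clear the scatter against an earlier compound, with a number 11.5 percentage points higher from compound 2 to compound 4 (beyond the scatter) for the change on the amine nitrogen and a number 11.5 percentage points higher from compound 1 to compound 4 (beyond the scatter) for the whole chain on the oxygen. Nothing available here accounts for this result. Open, going by these compounds, is how a phenyl ring, a pyridine ring or a simple methyl group on the carbonyl carbon would read out, and whether a longer chain to the amide nitrogen would alter the result.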